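The source may report more compounds than this note shows. Statements on the series, on what has been measured and on what is new or still open speak of the compounds shown alone.

Measured so far in a functional assay on MCF7 cells (Homo sapiens) for antiproliferative activity, read by sulforhodamine B assay, with a stated time of 48 h; on this read-out higher numbers stand for weaker inhibition and lower numbers for stronger inhibition:
Compound 1, `COc1ccc(NS(=O)(=O)c2ccc(N3CCNC3=O)cc2)cc1`: only a limit, > 1000 nM.
Compound 2, `CCc1ccc(NS(=O)(=O)c2ccc(N3CCNC3=O)cc2)cc1`: 810 nM.
Compound 3, `O=C1NCCN1c1ccc(S(=O)(=O)Nc2ccc(OC(F)F)cc2)cc1`: 760 nM.

Compound 3 and compound 2 lie within the scatter of each other (a 1.1-fold lower number from compound 2 to compound 3 (0.03 log units; within the scatter)), so neither stands apart on this read-out. Compound 4, `CCCCOc1ccc(NS(=O)(=O)c2ccc(N3CCNC3=O)cc2)cc1`, differs from compound 3 by butyl in place of difluoromethyl on an oxygen on an aromatic ring. Among the measured compounds shown here, the only step touching the group on that oxygen is an at least 1.3-fold lower number from compound 1 to compound 3 (0.11 log units; that floor lies within the scatter), which starts from a limit (the limit of > 1000 nM in this assay, at which 1 of the 3 values shown sits) and whose floor sits within the scatter; an at least 1.2-fold lower number from compound 1 to compound 2 (0.09 log units; that floor lies within the scatter) rests on the same limit. Nothing among these three compounds shows a change at this position moving the number beyond the scatter, so the step of a 1.1-fold lower number from compound 3 to compound 4 (0.04 log units; within the scatter) is expected to be small. Compound 4 is estimated at 700 nM, within 250 nM to 2000 nM.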

Compound 4, half-maximal inhibitory concentration: 870 nM
Compound 4: middle estimate off by 1.2-fold (0.09 log units), on the low side, within the range that was stated.
By their numbers in this assay, from the lowest: compounds 3, 2 and 4 (each within the scatter of the next). At a limit, above all of these: compound 1.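

The group on this oxygen now spans difluoromethyl and butyl with no step beyond the scatter in this assay: a 1.1-fold higher number from compound 3 to compound 4 (0.06 log units; within the scatter), and, with the butoxy compared against the ethyl on the aromatic carbon, a 1.1-fold higher number from compound 2 to compound 4 (0.03 log units; within the scatter). Lengthening the chain from methoxy to butoxy gives only a floor, an at least 1.1-fold lower number from compound 1 to compound 4 (0.06 log units; that floor lies within the scatter). Compound 1 remains a limit and not a number: the limit of > 1000 nM in this assay, at which 1 of the 4 values shown sits.

On these data alone, whether a chain longer than butyl, an amine or a carboxylic acid on this oxygen would move the number beyond the scatter remains open.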